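Working notes: trifluoromethyl to hydrogen step from compound 1

The source may report more compounds than this note shows. Statements on the series, on what has been measured and on what is new or still open speak of the compounds shown alone.

Measured so far:
compound 1, `OB(c1ccc(C(F)(F)F)cc1)c1ccc(C(F)(F)F)cc1`: 10800 nM
compound 2, `Fc1ccc([B-]2(c3ccccc3)[NH2+]CCO2)cc1`: 18800 nM

In an assay on HEK293 cells for inhibition of transient receptor potential cation channel subfamily V member 6 (Homo sapiens), read by FLIPR and calcium flux, with a stated time of 5 min (on this read-out lower numbers stand for stronger inhibition and higher numbers for weaker inhibition), compound 1 gives 10800 nM, and compound 2 gives 18800 nM. The two numbers lie within the usual scatter of each other, so neither compound is set apart on this read-out. Compound 3, `OB(c1ccccc1)c1ccc(C(F)(F)F)cc1`, differs from compound 1 by hydrogen in place of trifluoromethyl on an aromatic carbon. Going by the values given here, no pair of measured compounds shows this change, so its size is untested here. Compound 3 is expected to give 18000 nM (range 7000 nM to 50000 nM), with the estimated step of a 1.7-fold higher number from compound 1 to compound 3 (0.22 log units; within the scatter) leaning toward weaker inhibition but not clearly beyond the scatter.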

Compound 3, half-maximal inhibitory concentration: 11300 nM
Estimate against measurement, compound 3: 1.6-fold (0.20 log units) above, and the stated range covers the measured number.
By their numbers in this assay, from the lowest: compounds 1, 3 and 2 (each within the scatter of the next).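

In this assay, hydrogen in place of trifluoromethyl on an aromatic carbon, para to a large group, gives a 1.0-fold higher number from compound 1 to compound 3 (0.02 log units; within the scatter). Going by these compounds alone, this is the first direct reading of the change: at this position, loss of the trifluoromethyl group's four heavy atoms leaves no difference beyond the scatter. No measurement here bears on the reason for this.

From the compounds shown here alone, whether an amine or a carboxylic acid at this position would shift the number beyond the scatter remains open. So does the outcome of replacing the remaining trifluoromethyl of compound 3 with hydrogen.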